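Compound 4: Amino in Place of (Diethylamino)methyl

The compounds below may be only part of what the source reports. "The series", "measured", "known", "first", "only" and "open" are said of these compounds alone.

In an ADME assay on L02 cells (Homo sapiens) for cytotoxicity, read by MTT assay, with a stated time of 48 h (on this read-out higher numbers stand for weaker inhibition and lower numbers for stronger inhibition), compound 1 `CCN(CC)CCNC(=O)c1ccc(C(CC)(CC)c2ccc(OCC(O)C(C)(C)C)c(C)c2)n1CC` gives 2500 nM, compound 2 `CCn1c(C(=O)NCCN(C)C)ccc1C(CC)(CC)c1ccc(OCC(O)C(C)(C)C)c(C)c1` gives 2600 nM and compound 3 `CCN(CC)CCCNC(=O)c1ccc(C(CC)(CC)c2ccc(OCC(O)C(C)(C)C)c(C)c2)n1CC` gives 2500 nM. Compound 3 thus stands level with compound 1 and within the scatter of compound 2. Compound 4 `CCn1c(C(=O)NCCN)ccc1C(CC)(CC)c1ccc(OCC(O)C(C)(C)C)c(C)c1` carries amino in place of (diethylamino)methyl on a saturated chain carbon, two bonds along the chain from an amide-type nitrogen. Going by the values given here, the steps that bear on this are a 1.0-fold higher number from compound 1 to compound 2 (0.02 log units; within the scatter), no change at the digits printed from compound 1 to compound 3 (within the scatter) and a 1.0-fold lower number from compound 2 to compound 3 (0.02 log units; within the scatter), all within the scatter, yet no measured compound ends in plain amino. The expected result is a 1.1-fold higher number from compound 3 to compound 4 (0.05 log units; within the scatter), with no step beyond the scatter. Compound 4 is estimated at 2800 nM, with an expected range of 1300 nM to 6000 nM.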

Compound 4, half-maximal inhibitory concentration: 2400 nM
Beside the measured number, compound 4's estimate is 1.2-fold (0.07 log units) above it; the measured number falls inside the stated range.
By their numbers in this assay, from the lowest: compounds 4, 1, 3 and 2 (each within the scatter of the next).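

Plain amino, which brings a hydrogen-bond donor to the chain end, still leaves the number in this assay unmoved: a 1.0-fold lower number from compound 3 to compound 4 (0.02 log units; within the scatter) and a 1.1-fold lower number from compound 2 to compound 4 (0.03 log units; within the scatter) and a 1.0-fold lower number from compound 1 to compound 4 (0.02 log units; within the scatter) all lie within the scatter. Across all four compounds, then, this place takes amino as readily as the substituted amines. Nothing measured here offers an explanation for this flat result.

The compounds shown leave open whether a hydroxyl or a carboxylic acid in place of amino, or a ring amine such as morpholine, would move the number beyond the scatter.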